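Phenyl to tert-butyl on the shared core

This account rests on a few compounds, and the source may have more. Where it says the series, first, only, none or still open, it means among the compounds named here.

compound 1 `CC(C)n1nc(-c2cc(-c3ccccc3)on2)c2c(N)ncnc21` — > 10000 nM
compound 2 `CC(C)n1nc(/C=N/O)c2c(N)ncnc21` — > 10000 nM

Among the measured compounds shown here, both values measured so far in an assay on TT cells for inhibition of proto-oncogene tyrosine-protein kinase receptor Ret variant C634W (Homo sapiens), read by MTT assay, with a stated time of 10 days (on this read-out higher numbers stand for weaker inhibition of growth and lower numbers for stronger inhibition of growth), are limits of the assay rather than numbers. Compound 1 `CC(C)n1nc(-c2cc(-c3ccccc3)on2)c2c(N)ncnc21` gives > 10000 nM in this assay, which is a limit. Compound 2 `CC(C)n1nc(/C=N/O)c2c(N)ncnc21` gives > 10000 nM in this assay, likewise a limit. Where compound 1 stands can therefore only be stated against the limit of > 10000 nM in this assay, at which 2 of the 2 values shown sit: it sits at that limit together with compound 2, and no order between the two can be drawn from this.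

Compound 3 `CC(C)n1nc(-c2cc(C(C)(C)C)on2)c2c(N)ncnc21` differs from compound 1 by tert-butyl in place of phenyl on an aromatic carbon. For the measured compounds named here, no step between measured compounds connects a change of this kind to the read-out, so there is nothing to size the change against. Compound 1 rests at a limit, and the step of a number no higher from compound 1 to compound 3 (the limit leaves the size open) is expected to be none beyond the scatter. Compound 3 is estimated at 10000 nM in this assay, within 2500 nM to 40000 nM, with the assay most likely again reporting only a limit rather than a number.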

Compound 3, concentration for 50% growth inhibition: > 10000 nM
Compound 3 was reported as a limit (the forecaster's own chance of this, stated with the estimate: 70%); the middle value lies on the limit itself.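

In this assay no step can be read from compound 1 to compound 3, because both results are limits of the assay rather than numbers: the limit of > 10000 nM in this assay, at which 3 of the 3 values shown sit.

Still open, on these data alone, is whether tert-butyl in place of phenyl on the aromatic carbon changes growth inhibition at all, and how far each compound lies past that limit.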